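The source may report more compounds than this note shows. Statements on the series, on what has been measured and on what is new or still open speak of the compounds shown alone.

Measured so far:
compound 1 `CCN(CC)CCCNC(=O)c1ccc(C(CC)(CC)c2ccc(OCC(=O)C(C)(C)C)c(C)c2)n1CC` — 530 nM
compound 2 `CCN(CC)CCCNC(=O)c1ccc(C(CC)(CC)c2ccc(OCC(O)C(C)(C)C)c(C)c2)n1CC` — 190 nM

In a functional assay on MCF7 cells (Homo sapiens), read by MTT assay, with a stated time of 48 h (on this read-out higher numbers stand for weaker inhibition and lower numbers for stronger inhibition), compound 2 gives 190 nM, the lowest of the two numbers. Compound 1 gives 530 nM. Among the compounds with values here, the only measured step, a 2.8-fold lower number from compound 1 to compound 2 (0.45 log units; beyond the scatter), lies at the chain on the aromatic-ring oxygen, far from the amide.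

Compound 3 `CCn1c(C(=O)N(C)CC(=O)O)ccc1C(CC)(CC)c1ccc(OCC(O)C(C)(C)C)c(C)c1` differs from compound 2 in one place: (carboxymethyl)(methyl)amino in place of (3-(diethylamino)propyl)amino on a carbonyl carbon. Within the data shown here, no measured step bears on a change at this carbonyl carbon; the one step in hand concerns a different part of the shared core, so it offers no guide to direction or size here. The estimate for compound 3 is therefore wide. In this assay compound 3 is expected to give a step of a 3.2-fold higher number from compound 2 to compound 3 (0.50 log units; beyond the scatter), a modest weakening with little confidence. The estimated value for compound 3 is 600 nM, in a range from 150 nM to 3000 nM.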

Compound 3, half-maximal inhibitory concentration: 25400 nM
Compound 3: the middle estimate sits 42-fold (1.63 log units) below what was measured; the measured number lies above the stated range.
By their numbers in this assay, from the lowest: compound 2; then compound 1; then compound 3.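

In this assay, within the data shown here, the carbonyl carbon proves to be a much more sensitive place than the chain on the aromatic-ring oxygen: a 130-fold higher number from compound 2 to compound 3 (2.13 log units; beyond the scatter), whereas the only earlier change gave a 2.8-fold lower number from compound 1 to compound 2 (0.45 log units; beyond the scatter). This one change replaces the whole (3-(diethylamino)propyl)amino group with (carboxymethyl)(methyl)amino, so the chain, its end group and the methyl on the amide nitrogen all change together, and the step cannot be assigned to any one of them. Nothing available explains the size of this step.

The compounds shown leave open whether the diethylamino end, the carboxylic acid or the added methyl accounts for the step. A shorter or longer amine-bearing chain, a carboxylic acid chain without that methyl, or a neutral ester at this carbonyl carbon would separate these parts.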